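A few compounds are considered here, and "the series" means these few. Any claim that something is new, unique, unknown or untested is made for them only; others in the source may bear on it.

Three compounds have been measured in a functional assay on Shh Light II cells (Mus musculus) for inhibition, read by a luciferase reporter; a lower number here means a stronger inhibitor, a higher number a weaker inhibitor:

Compound 1, `Cc1noc(C)c1NC(=O)N1CCC(c2nc(-c3ccc4ccccc4n3)no2)CC1`, gives 3000 nM.
Compound 2, `O=C(Nc1ncccc1Cl)N1CCC(c2nc(-c3ccc4ccccc4n3)no2)CC1`, gives 2800 nM.
Compound 3, `O=C(NC1CCS(=O)(=O)CC1)N1CCC(c2nc(-c3ccc4ccccc4n3)no2)CC1`, gives 360 nM.

Compound 3 has the lowest number of the three; the nearest is compound 2, and the step of a 7.8-fold lower number from compound 2 to compound 3 (0.89 log units; beyond the scatter) lies beyond the scatter, as does an 8.3-fold lower number from compound 1 to compound 3 (0.92 log units; beyond the scatter). Between compound 1 and compound 2 the step of a 1.1-fold lower number from compound 1 to compound 2 (0.03 log units; within the scatter) is within the scatter.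

Compound 4, `O=C(Nc1cccc2cccnc12)N1CCC(c2nc(-c3ccc4ccccc4n3)no2)CC1`, is not yet measured. The change from compound 3 reads (quinolin-8-yl in place of 1,1-dioxothian-4-yl on an amide-type nitrogen). The two steps that bear on it both run toward compound 3: in an 8.3-fold lower number from compound 1 to compound 3 (0.92 log units; beyond the scatter) and a 7.8-fold lower number from compound 2 to compound 3 (0.89 log units; beyond the scatter) the 1,1-dioxothian-4-yl gave a lower number than a six-membered aromatic ring with one hetero atom or a 1,2-oxazole on the same amide-type nitrogen. Compound 4 carries a quinolin-8-yl there, so the number of compound 4 is expected to move back up, with a step of about a 6.9-fold higher number from compound 3 to compound 4 (0.84 log units; beyond the scatter). For compound 4 the estimate in this assay is 2500 nM, between 800 nM and 8000 nM.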

Compound 4, half-maximal inhibitory concentration: 1400 nM
Beside the measured number, compound 4's estimate is 1.8-fold (0.25 log units) above it, and the stated range covers the measured number.
By their numbers in this assay, from the lowest: compound 3; then compounds 4, 2 and 1 (each within the scatter of the next, the first and the last beyond it).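

In this assay, a two-ring aromatic group on this amide-type nitrogen does not match the 1,1-dioxothian-4-yl: the change gives a 3.9-fold higher number from compound 3 to compound 4 (0.59 log units; beyond the scatter), so the lead of the non-aromatic ring now holds against three different aromatic groups. The aromatic groups themselves are not all equal, since quinolin-8-yl shows a 2.0-fold lower number from compound 2 to compound 4 (0.30 log units; within the scatter), which leaves it level with 3-chloropyridin-2-yl, and a 2.1-fold lower number from compound 1 to compound 4 (0.33 log units; beyond the scatter), a modest separation from 3,5-dimethyl-1,2-oxazol-4-yl. No measurement shown explains either the lead of compound 3 or these smaller differences.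

From the compounds shown here alone, it remains open whether compound 3 owes its number to the two sulfonyl oxygens or to the saturated ring, a question that a cyclohexyl or an oxan-4-yl on this nitrogen would address. Going by these compounds, all four compounds share one core, so whether this order holds on any other core also stays open.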